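Extending the nitrile chain of an allyl acetophenone series

A few compounds are considered here, and "the series" means these few. Any claim that something is new, unique, unknown or untested is made for them only; others in the source may bear on it.

Three compounds sharing one core were tested in an assay on isolated protein for inhibition of leukotriene B4 receptor 1 (Homo sapiens), tested at 10 uM; a higher number here means more inhibition at the concentration tested (going by the name of the read-out), a lower number less inhibition. Compound 1 `C=CCc1cc(C(C)=O)c(O)cc1OCCCCCCC#N` gives 97%. Compound 2 `C=CCc1cc(C(C)=O)c(O)cc1OCCCCCCCC#N` gives 88%. Compound 3 `C=CCc1cc(C(C)=O)c(O)cc1OCCCCCCCCC#N` gives 86%. Among the measured compounds shown here, of the three numbers, the one for compound 3 is the lowest, though the step of a number 2 percentage points lower from compound 2 to compound 3 (within the scatter) stays within the scatter and only a number 11 percentage points lower from compound 1 to compound 3 (beyond the scatter) goes beyond it; the step of a number 9 percentage points lower from compound 1 to compound 2 (within the scatter) also stays within the scatter.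

Compound 4 `C=CCc1cc(C(C)=O)c(O)cc1OCCCCCCCCCCC#N` has not yet been measured in this assay. It differs from compound 3 in that (2-cyanoethyl in place of cyano on a saturated chain carbon, eight bonds along the chain from an oxygen on an aromatic ring). The step that bears most directly on this change is the one that likewise put 2-cyanoethyl in place of cyano, a number 11 percentage points lower from compound 1 to compound 3 (beyond the scatter), a modest loss, while the one-carbon extensions a number 9 percentage points lower from compound 1 to compound 2 (within the scatter) and a number 2 percentage points lower from compound 2 to compound 3 (within the scatter) each stayed within the scatter. A further modest downward step in this assay is therefore expected, roughly of the size a number 9 percentage points lower from compound 3 to compound 4 (within the scatter). Compound 4 is estimated at 77%, with a range from 64% to 90%.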

Compound 4, a percentage reported as inhibition, at one concentration (the size of the read-out at that concentration, not a potency): 50%
Beside the measured number, compound 4's estimate is 27 percentage points above it; the whole stated range lies above it.
By their numbers in this assay, from the lowest: compound 4; then compounds 3, 2 and 1 (each within the scatter of the next, the first and the last beyond it).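

In this assay, the 2-cyanoethyl change at this place, eight bonds along the chain from an oxygen on an aromatic ring, gives a number 36 percentage points lower from compound 3 to compound 4 (beyond the scatter), far more than the same change two carbons earlier, a number 11 percentage points lower from compound 1 to compound 3 (beyond the scatter), so its cost depends on where along the chain it is made. The shorter chains show the same gap, with a number 38 percentage points lower from compound 2 to compound 4 (beyond the scatter) and a number 47 percentage points lower from compound 1 to compound 4 (beyond the scatter), which sets compound 4 apart from the other three compounds rather than extending a gentle slope. Nothing available here accounts for this loss.

The compounds shown leave open whether the fall is abrupt or graded over the intervening chain length, and whether a longer chain loses still more. They also leave open whether an amine or a carboxylic acid in place of the nitrile would restore inhibition on the long chain.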